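A few compounds are considered here, and "the series" means these few. Any claim that something is new, unique, unknown or untested is made for them only; others in the source may bear on it.

Of the compounds shown here, two have been measured so far in an assay on CHO cells for displacement of a labelled ligand from 5-hydroxytryptamine receptor 7 (Homo sapiens), read by scintillation counting, with a stated time of 120 min; a lower number here means a stronger inhibitor, a higher number a weaker inhibitor. Compound 1 `Fc1ccc2[nH]cc(CCCN3CCN(c4ccccc4-c4ccccc4)CC3)c2c1` gives 1.1 nM in this assay. Compound 2 `Fc1cccc(-c2cc(F)ccc2N2CCN(CCCc3c[nH]c4ccc(F)cc34)CC2)c1` gives 12 nM in this assay, the highest of the two numbers, and its nearest neighbour is compound 1, whose number lies well below it, beyond the usual scatter of this kind of measurement. Compound 3 `Fc1ccc(N2CCN(CCCc3c[nH]c4ccc(F)cc34)CC2)c(-c2ccccc2)c1` is the next to be measured in this assay. Going from compound 2 to compound 3, the change is hydrogen in place of fluoro on an aromatic carbon. Within the data shown here, no step between two measured compounds covers this kind of change, so there is no direct precedent to lean on. Since compound 1 gives 1.1 nM, a lower number than compound 2, a moderate decrease is expected for the step of a 3.0-fold lower number from compound 2 to compound 3 (0.48 log units; beyond the scatter). Compound 3 is therefore estimated at 4 nM, with a likely range from 1.5 nM to 12 nM.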

Compound 3, inhibition constant: 3.3 nM
Estimate against measurement, compound 3: 1.2-fold (0.08 log units) above; the measured number falls inside the stated range.
By their numbers in this assay, from the lowest: compound 1; then compound 3; then compound 2.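

In this assay, changing 3-fluorophenyl to phenyl gives a 3.6-fold lower number from compound 2 to compound 3 (0.56 log units; beyond the scatter) and so shows that this fluoro, on its own, weakens binding. The other single change, fluoro in place of hydrogen on an aromatic carbon, gives a 3.0-fold higher number from compound 1 to compound 3 (0.48 log units; beyond the scatter) and points the same way at a second place. The wide gap between compound 1 and compound 2 therefore splits into two steps, each beyond the usual scatter, and in these three compounds every added fluoro goes with a higher number.

On these data alone, whether this holds only for fluoro stays open, since a chloro, methyl or methoxy group at either place could behave differently. Nothing measured here explains why either fluoro raises the number.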